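Swapping fluoro for methyl on the carboxyphenyl ether

The compounds below may be only part of what the source reports. "The series", "measured", "known", "first", "only" and "open" are said of these compounds alone.

Measured so far:
compound 1, `Cc1cc(OCCCCOc2ccc(C(=O)CC3CCCC3)c(O)c2C)ccc1C(=O)O`: 55%
compound 2, `COc1ccc(C(=O)O)cc1OCCCCOc1ccc(C(=O)CC2CCCC2)c(O)c1C`: 14%
compound 3, `Cc1c(OCCCCOc2ccc(C(=O)O)cc2F)ccc(C(=O)CC2CCCC2)c1O`: 66%

Three compounds share a core and differ only in the aryl group carried on an oxygen on a saturated carbon. In an ADME assay (liver) for metabolic stability, with Liver microsome (Rattus norvegicus) as the target, read by LC-MS, using microsomes and NADPH, with stated times of 5 min and 60 min, tested at 4 uM (on this read-out lower numbers stand for a less stable compound and higher numbers for a more stable compound), compound 3 stands highest of the three: compound 1 sits nearest, the step being a number 11 percentage points higher from compound 1 to compound 3 (beyond the scatter), and compound 2 sits furthest, with a number 52 percentage points higher from compound 2 to compound 3 (beyond the scatter). Compound 1 and compound 2 are themselves separated by a number 41 percentage points lower from compound 1 to compound 2 (beyond the scatter).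

The next compound, compound 4, `Cc1cc(C(=O)O)ccc1OCCCCOc1ccc(C(=O)CC2CCCC2)c(O)c1C`, has not yet been measured in this assay. It differs from compound 3 by methyl in place of fluoro on an aromatic carbon. Among the compounds with values here, no measured step shows exactly this exchange. The step from compound 1 to compound 3 comes closest, as it replaces a methyl-bearing carboxyphenyl with the fluoro-bearing one, and it was modest at a number 11 percentage points higher from compound 1 to compound 3 (beyond the scatter). The large steps involving compound 2 concern a methoxy-bearing ring and bear less on the present change. A modest step in this assay, downward or none beyond the scatter, is therefore expected: a number 8 percentage points lower from compound 3 to compound 4 (within the scatter). Compound 4 is estimated at 58%, within a range from 40% to 72%.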

Compound 4, percent of the compound remaining: 59%
For compound 4 the middle estimate is 1 percentage points below the measured one; low and high end bracket the measured number.
By their numbers in this assay, from the lowest: compound 2; then compounds 1, 4 and 3 (each within the scatter of the next, the first and the last beyond it).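

In this assay, the exchange of fluoro for methyl on an aromatic carbon, ortho to a large group and meta to a carboxy group, gives a number 7 percentage points lower from compound 3 to compound 4 (within the scatter), so at this place the two groups cannot be told apart. Shifting the methyl on the carboxyphenyl ring gives a number 4 percentage points higher from compound 1 to compound 4 (within the scatter), which leaves compound 4 within the scatter of both compound 1 and compound 3, while the methoxy-bearing ring of compound 2 stays well apart, with a number 45 percentage points higher from compound 2 to compound 4 (beyond the scatter). No measurement shown here accounts for any of these steps.

The compounds shown leave open whether the low number of compound 2 goes with its methoxy group or with the place of its carboxy group, as the two change together in that ring. They also leave open what a chloro group or a nitrile would give at the place held by fluoro and methyl, and how an amide in place of the carboxylic acid would read.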